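Ethyl Capping of the Carboxamide in Compound 1

The source may hold more compounds than are shown below. What is called first, only, known or untested is meant among the compounds shown, and "the series" means these compounds.

Compound 1 `CC[C@@H]1C(=O)N(C)c2cnc(-n3ccc4cc(C(N)=O)ccc43)nc2N1C1CCCC1` stands as the stronger of the two compounds measured in a functional assay on HeLa cells (Homo sapiens) for antiproliferative activity, read by CCK-8 assay, with a stated time of 72 h (a higher number here means a weaker inhibitor of growth, a lower number a stronger inhibitor of growth), where compound 1 gives 674 nM. Compound 2 `CCCCNC(=O)c1ccc2c(ccn2-c2ncc3c(n2)N(c2ccn(C)n2)C(CC)C(=O)N3C)c1` differs from it in more than one place, and in this assay compound 2 gives 4260 nM, a weaker result beyond the scatter. Compound 3 `CCNC(=O)c1ccc2c(ccn2-c2ncc3c(n2)N(C2CCCC2)[C@H](CC)C(=O)N3C)c1` carries the change ethyl in place of hydrogen on an amide-type nitrogen relative to compound 1 and has not yet been measured. Among the compounds with values here, with no single-change step on record, a modest weakening is expected, a 1.5-fold higher number from compound 1 to compound 3 (0.17 log units; within the scatter), close to the scatter. Compound 3 is therefore estimated at 1000 nM, with a range from 350 nM to 3000 nM.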

Compound 3, concentration for 50% growth inhibition: 418 nM
Compound 3: middle estimate off by 2.4-fold (0.38 log units), on the high side, within the range that was stated.
By their numbers in this assay, from the lowest: compounds 3 and 1 (each within the scatter of the next); then compound 2.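

On the amide-type nitrogen, ethyl in place of hydrogen gives a 1.6-fold lower number from compound 1 to compound 3 (0.21 log units; within the scatter) in this assay, so this assay does not tell compound 1 and compound 3 apart. Within the data shown here, the amide hydrogen of compound 1 is therefore not needed to keep growth inhibition at this level, a point that the earlier compounds, which differ in more than one place, could not show. Nothing on hand explains why the ethyl group is accepted here. Still open, on these data alone, is whether a benzyl group, a hydroxyethyl chain or a second ethyl on the same nitrogen would be accepted as well.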